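This account rests on a few compounds, and the source may have more. Where it says the series, first, only, none or still open, it means among the compounds named here.

Compound 1, `CCCCN(c1nc2c(C(=O)NC)cccc2o1)[C@H](C)c1ccc(-c2ccccc2-c2nnn[nH]2)cc1`, and compound 2, `CCCCN(c1nc2c(-c3nccn3C)cccc2o1)[C@H](C)c1ccc(-c2ccccc2-c2nnn[nH]2)cc1`, share one core and differ in a single group on the aromatic carbon of the fused system. In an ADME assay on the whole organism (Macaca fascicularis) for metabolic stability, read by LC-MS, using cassette dosing, at a dose of 1 mg/kg by the oral route (a lower number here means that the compound disappears faster, a higher number that the compound lasts longer), compound 1 gives 1.3 h, and compound 2 gives 3.9 h. For the measured compounds named here, the one measured step, a 3.0-fold higher number from compound 1 to compound 2 (0.48 log units; beyond the scatter), put 1-methyl-1H-imidazol-2-yl in place of methylcarbamoyl. Compound 2 thus holds the highest of the two numbers, with compound 1 the nearest and lower.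

Compound 3, `CCCCN(c1nc2c(C(=O)NS(C)(=O)=O)cccc2o1)[C@H](C)c1ccc(-c2ccccc2-c2nnn[nH]2)cc1`, has not been measured. It differs from compound 2 by (methylsulfonyl)carbamoyl in place of 1-methyl-1H-imidazol-2-yl on an aromatic carbon. Going by the values given here, the only step that bears on this change is a 3.0-fold higher number from compound 1 to compound 2 (0.48 log units; beyond the scatter), which went from a carbamoyl group to the imidazolyl ring and raised the half-life. Among the compounds with values here, compound 3 takes that imidazolyl ring away again and puts a carbamoyl-type group back, so the expectation is a step in the opposite direction, of a size not far from the measured one, though no measured pair contains the (methylsulfonyl)carbamoyl group itself. Compound 3 is therefore expected to give 1.8 h in this assay, within 0.8 h to 4 h, which means an estimated step of a 2.2-fold lower number from compound 2 to compound 3 (0.34 log units; beyond the scatter).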

Compound 3, half-life: 2.7 h
The estimate for compound 3 lay 1.5-fold (0.18 log units) below the measured number; measured number inside the range.
By their numbers in this assay, from the lowest: compound 1; then compounds 3 and 2 (each within the scatter of the next).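

In this assay, methylsulfonyl in place of methyl on an amide-type nitrogen gives a 2.1-fold higher number from compound 1 to compound 3 (0.32 log units; beyond the scatter), which shows that the half-life at this aromatic carbon does not depend on having the 1-methyl-1H-imidazol-2-yl ring there, since an acyclic group also stands clear of the methylcarbamoyl compound. Exchanging that ring for (methylsulfonyl)carbamoyl gives a 1.4-fold lower number from compound 2 to compound 3 (0.16 log units; within the scatter), so the two compounds cannot be told apart in this read-out even though the groups they carry at this position share neither a ring nor their atom make-up. Nothing measured here accounts for the way either group differs from methylcarbamoyl in its effect on the half-life.

Going by these compounds, what remains open is whether replacing the methyl on the sulfonyl with a cyclopropyl or phenyl group would keep the half-life in this range, and whether a carboxylic acid or a nitrile on the same aromatic carbon would fall with compound 1 or with compound 2 and compound 3. On these data alone, it is also open whether these differences would hold with a propyl or pentyl chain in place of the butyl chain on the shared core.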